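The source may report more compounds than this note shows. Statements on the series, on what has been measured and on what is new or still open speak of the compounds shown alone.

Three compounds have been measured in an assay on cells for inhibition of cytochrome P450 11B1, mitochondrial (Homo sapiens); a lower number here means a stronger inhibitor, a higher number a weaker inhibitor:

- compound 1 `C[C@@H](c1ccc(Cl)cc1)N1Cc2cncn2C(CC2(C)COC2)S1(=O)=O`, 340 nM
- compound 2 `CC(C)CC1n2cncc2CN(Cc2ccccc2)S1(=O)=O`, 103 nM
- compound 3 `C[C@@H](c1ccc(Cl)cc1)N1Cc2cncn2C(C[C@@H](O)c2ccccc2)S1(=O)=O`, 234 nM

Compound 1 stands at the highest number of the three, although its gap to compound 3 lies within the scatter; only compound 2 sits clearly lower. The unmeasured compound 4 `CC(C)CC1n2cncc2CN([C@@H](C)c2ccc(Cl)cc2)S1(=O)=O` differs from compound 1 in one place: isopropyl in place of 3-methyloxetan-3-yl on a saturated chain carbon bound to a saturated ring carbon.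

For the measured compounds named here, one measured step bears on this position. The step of a 1.5-fold lower number from compound 1 to compound 3 (0.16 log units; within the scatter) swapped the same group for another and moved the number only within the scatter, so this position has so far tolerated exchange without a clear effect. Compound 2 carries the same isobutyl as compound 4 but a different group on the ring nitrogen, so its value shows only that this chain is compatible with a low number. The expectation for compound 4 is therefore a step of a 1.7-fold lower number from compound 1 to compound 4 (0.23 log units; within the scatter) that stays within the scatter, perhaps leaning to a lower number. Compound 4 is estimated at 200 nM, in the range 80 nM to 500 nM.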

Compound 4, half-maximal inhibitory concentration: 76 nM
Beside the measured number, compound 4's estimate is 2.6-fold (0.42 log units) above it, and the stated range ends above it.
By their numbers in this assay, from the lowest: compounds 4 and 2 (each within the scatter of the next); then compounds 3 and 1 (each within the scatter of the next).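

In this assay, for the compounds shown here, isopropyl on a saturated chain carbon bound to a saturated ring carbon brings a 4.5-fold lower number from compound 1 to compound 4 (0.65 log units; beyond the scatter) and also a 3.1-fold lower number from compound 3 to compound 4 (0.49 log units; beyond the scatter) so this position is not as indifferent to exchange as the one earlier step, which stayed within the scatter, had suggested. Among the three compounds that share the same group on the ring nitrogen, the all-carbon, ring-free isopropyl gives the lowest number, with both steps beyond the scatter. Nothing measured here explains why the number falls at this position.

Isopropyl differs from 3-methyloxetan-3-yl in its ring, its oxygen and its heavy-atom count all at once, so the compounds shown cannot separate these differences. A cyclopropyl group, which keeps a ring without oxygen, or a longer chain such as n-butyl at this place would begin to pull them apart.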